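Adding a Methyl to the Amide Nitrogen of Compound 2

The source may hold more compounds than are shown below. What is called first, only, known or untested is meant among the compounds shown, and "the series" means these compounds.

In a functional assay on the whole organism for inhibition, with Rattus norvegicus as the target, at a dose of 10 mg/kg by the oral route (on this read-out lower numbers stand for less inhibition and higher numbers for more inhibition at the one dose given (going by the name of the read-out)), compound 1 `COc1cccc([C@H]2O[C@H](CC(=O)NCCCCC(=O)O)C(=O)N(CC(C)(C)CO)c3ccc(Cl)cc32)c1OC` gives 50% and compound 3 `COc1cccc([C@H]2O[C@H](CC(=O)N3CCC(CC(=O)O)CC3)C(=O)N(CC(C)(C)COCC(=O)OC(C)(C)C)c3ccc(Cl)cc32)c1OC` gives 43%, while compound 2 `COc1cccc([C@H]2O[C@H](CC(=O)NCC(=O)O)C(=O)N(CC(C)(C)CO)c3ccc(Cl)cc32)c1OC` gives 14%, the lowest of the three numbers. Among the compounds with values here, the only measured step among them, a number 36 percentage points lower from compound 1 to compound 2 (beyond the scatter), concerns the chain on the carbon bound to the amide-type nitrogen and does not touch the nitrogen itself. Compound 4 `COc1cccc([C@H]2O[C@H](CC(=O)N(C)CC(=O)O)C(=O)N(CC(C)(C)CO)c3ccc(Cl)cc32)c1OC` differs from compound 2 by methyl in place of hydrogen on an amide-type nitrogen. Within the data shown here, no measured step alters a substituent on this nitrogen, so nothing among the three compounds bears directly on the change, and the step is therefore expected to stay within the usual scatter. For compound 4 the expected value is 20%, within 5% to 45%, an expected step of a number 6 percentage points higher from compound 2 to compound 4 (within the scatter).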

Compound 4, a percentage reported as inhibition, in the whole organism at one dose (the size of the read-out at that dose, not a potency): -1%
For compound 4 the middle estimate is 21 percentage points above the measured one; measured number outside the range, below it.
By their numbers in this assay, from the lowest: compound 4; then compound 2; then compounds 3 and 1 (each within the scatter of the next).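

The step of a number 15 percentage points lower from compound 2 to compound 4 (beyond the scatter) in this assay shows that methyl in place of hydrogen on this amide-type nitrogen is not a silent change, though it adds only one carbon. With (carboxymethyl)(methyl)amino in place of (4-carboxybutyl)amino on the carbonyl carbon, the step of a number 51 percentage points lower from compound 1 to compound 4 (beyond the scatter) is the largest in this set. No supporting measurement accounts for either drop. Still open, from the compounds shown here alone, is whether ethyl on this nitrogen behaves like methyl, and whether methyl has the same effect on the (4-carboxybutyl)amino group of compound 1.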